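A few compounds are considered here, and "the series" means these few. Any claim that something is new, unique, unknown or untested is made for them only; others in the source may bear on it.

In an ADME assay on HepG2 cells (Homo sapiens) for inhibition, read by fluorescence and resazurin assay, with a stated time of 72 h (on this read-out higher numbers stand for weaker inhibition and lower numbers for stronger inhibition), compound 1 `NS(=O)(=O)c1ccc(Nc2nccc(Nc3ccc4nc[nH]c4c3)n2)cc1` reads > 25000 nM, which is a limit of the assay. Compound 3 `Cc1c2ccc(Nc3ccnc(Nc4ccc(S(N)(=O)=O)cc4)n3)cc2nn1C` reads > 25000 nM, also a limit. For the measured compounds named here, compound 2 `NS(=O)(=O)c1ccc(Nc2nccc(Nc3ccc4cn[nH]c4c3)n2)cc1` gives 22000 nM, the only actual number among the three.

Compound 4 `Brc1ccc(Nc2nccc(Nc3ccc4cn[nH]c4c3)n2)cc1` carries bromo in place of sulfamoyl on an aromatic carbon, counted as bromo in place of sulfamoyl on an aromatic carbon. Going by the values given here, the one measured step, an at least 1.1-fold lower number from compound 1 to compound 2 (0.05 log units; that floor lies within the scatter), lies in another part of the molecule and stays within the scatter, so it offers little guidance. Readings here crowd against (the limit of > 25000 nM in this assay, at which 2 of the 3 values shown sit), leaving room for a clear change mainly toward stronger inhibition. The expected step, toward a lower number, is a 2.4-fold lower number from compound 2 to compound 4 (0.39 log units; beyond the scatter). For compound 4 the estimate is 9000 nM, with an expected range from 2500 nM to 25000 nM.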

Compound 4, half-maximal inhibitory concentration: 20000 nM
The estimate for compound 4 lay 2.2-fold (0.35 log units) below the measured number; measured number inside the range.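

In this assay, bromo in place of sulfamoyl on an aromatic carbon gives a 1.1-fold lower number from compound 2 to compound 4 (0.04 log units; within the scatter), so the two readings cannot be told apart. Sulfamoyl, with its hydrogen-bond donor and acceptors, is therefore not required at this position for a reading of this size, since bromo, which has neither, reads alike. The two readings also lie not far from a ceiling, which limits what this comparison can show: the limit of > 25000 nM in this assay, at which 2 of the 4 values shown sit.

As far as these compounds go, whether an amine, a carboxylic acid or a longer chain on this carbon would read differently remains open. So does whether any group here can bring a clear move toward stronger inhibition.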